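Fluorine on Two Rings in an HL-60 Activation Series

This account rests on a few compounds, and the source may have more. Where it says the series, first, only, none or still open, it means among the compounds named here.

Compound 1 `COc1ccc(-n2cnc3cnc(-c4ccccc4C)cc32)cc1OC` gives 69 nM in a functional assay on HL-60 cells (Homo sapiens) for activation, read by flow cytometry, with a stated time of 4 days; on this read-out higher numbers stand for an effect only at larger amounts of compound and lower numbers for an effect already at smaller amounts. Compound 2 `COc1ccc(-n2cnc3cnc(-c4ccc(F)cc4C)cc32)cc1OC` carries the change fluoro in place of hydrogen on an aromatic carbon and in this assay compound 2 gives 15 nM, a step of a 4.6-fold lower number from compound 1 to compound 2 (0.66 log units; beyond the scatter). Compound 3 `COc1ccc(-n2cnc3cnc(-c4ccc(F)cc4C)cc32)cc1` has a hydrogen where compound 2 has a methoxy group, and in this assay compound 3 gives 6 nM, a further step of a 2.5-fold lower number from compound 2 to compound 3 (0.40 log units; beyond the scatter) and the lowest number among the three measured compounds. Compound 4 `COc1ccc(-n2cnc3cnc(-c4ccc(F)cc4C)cc32)cc1F` has not been measured; it differs from compound 3 by fluoro in place of hydrogen on an aromatic carbon. For the measured compounds named here, this is the same kind of change as the one from compound 1 to compound 2, not the same: there the fluoro entered meta to a methyl group and para to a large group, here it enters ortho to a methoxy group and meta to a large group, on a different ring. The difference between the cores of compound 1 and compound 3 is not broken down here. Going by the values given here, the step from compound 3 to compound 4 in this assay is expected to be a 1.2-fold lower number from compound 3 to compound 4 (0.08 log units; within the scatter), smaller than the earlier one, because a 4.6-fold lower number from compound 1 to compound 2 (0.66 log units; beyond the scatter) was measured on another ring and no measured compound shows a fluoro at the new place. Compound 4 is estimated at 5 nM, expected between 1.5 nM and 15 nM.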

Compound 4, half-maximal effective concentration: 10 nM
Beside the measured number, compound 4's estimate is 2.0-fold (0.30 log units) below it, and the stated range covers the measured number.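

In this assay, fluoro in place of hydrogen ortho to a methoxy group gives a 1.7-fold higher number from compound 3 to compound 4 (0.22 log units; within the scatter), and fluoro in place of methoxy gives a 1.5-fold lower number from compound 2 to compound 4 (0.18 log units; within the scatter), so neither step can be told apart from the ordinary variation between repeated measurements. The same kind of change therefore did not carry over with the same size from one core to the other, since the new step and the earlier one clearly differ: the same change on two cores in this assay, a 4.6-fold lower number (0.66 log units; beyond the scatter) from compound 1 to compound 2 and a 1.7-fold higher number (0.22 log units; within the scatter) from compound 3 to compound 4, 7.7-fold (0.88 log units) apart, beyond the scatter of two such steps This comparison does not show whether the core or the place of the fluoro accounts for that gap, as the two steps differ in both, and one pair of steps gives no rule for the wider series.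

The compounds shown leave open how a fluoro ortho to a methoxy group would behave on the core of compound 1. They also leave open what other groups at that place, such as a chlorine, a nitrile or an amine, would do in this assay.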